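The compounds below may be only part of what the source reports. "The series", "measured", "known", "first", "only" and "open" are said of these compounds alone.

Compound 1 `CC(=O)OC[C@H]1O[C@@H](SCc2nnn(-c3ccc(S(N)(=O)=O)cc3)c2I)[C@H](OC(C)=O)[C@@H](OC(C)=O)[C@@H]1OC(C)=O` was examined in an ADME assay on NFF cells (Homo sapiens) for cytotoxicity, read by sulforhodamine B assay, with a stated time of 3 days (a higher number here means a weaker inhibitor, a lower number a stronger inhibitor), where compound 1 gives 51100 nM, the only numerical result among the two values recorded. Compound 2 `CC(=O)OC[C@H]1O[C@@H](OCc2nnn(-c3ccc(S(N)(=O)=O)cc3)c2I)[C@H](OC(C)=O)[C@@H](OC(C)=O)[C@@H]1OC(C)=O` was also tested; in this assay compound 2 returns > 100000 nM, which is a limit of the assay rather than a number (the limit of > 100000 nM in this assay, at which 1 of the 2 values shown sits). Compound 3 `CC(=O)OC[C@H]1O[C@@H](SCc2nnn(-c3ccc(S(N)(=O)=O)cc3)c2I)[C@H](OC(C)=O)[C@@H](OC(C)=O)[C@H]1OC(C)=O` differs from compound 1 in configuration alone: the two compounds have the same atoms and bonds and differ only in configuration as drawn: 1 of 5 stereo elements differ; a stereocentre at a saturated ring carbon is drawn R in compound 1 and S in compound 3. Going by the values given here, no measured pair isolates such a change, so the step from compound 1 to compound 3 in this assay is expected to stay within the scatter, estimated as a 1.1-fold higher number from compound 1 to compound 3 (0.03 log units; within the scatter). Compound 3 is therefore expected to give about 55000 nM, between 25000 nM and 120000 nM.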

Compound 3, half-maximal inhibitory concentration: > 100000 nM
Compound 3: no number, only a limit; the forecaster's own chance of this, stated with the estimate: 30%; middle value at least 1.8-fold (0.25 log units) from the limit.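

Going by these compounds alone, the step at this saturated ring carbon, an at least 1.9-fold higher number from compound 1 to compound 3 (0.29 log units; that floor lies within the scatter), is the first reading of a change in configuration alone, with atoms and bonds the same: the fact that compounds 1 and 3 differ only in the configuration as drawn. Compound 3 gives a limit and not a number, so this step is only a floor and its true size cannot be read: the limit of > 100000 nM in this assay, at which 2 of the 3 values shown sit. The compounds shown leave open how configuration at the other stereocentres bears on this result. They also leave open whether free hydroxyl groups in place of the acetate esters would give numbers rather than limits.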